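A few compounds are considered here, and "the series" means these few. Any claim that something is new, unique, unknown or untested is made for them only; others in the source may bear on it.

Three compounds from a series sharing one core have numbers in a functional assay on DU-145 cells (Homo sapiens) for inhibition, read by trypan blue exclusion, with a stated time of 96 h; a higher number here means a weaker inhibitor of growth, a lower number a stronger inhibitor of growth. Compound 1 `O=C(/C(=C\c1ccc(Br)cc1)SCc1ccc(Cl)cc1)c1ccc(Cl)cc1` gives 1000 nM in this assay. Compound 2 `COc1cc(OC)c(/C=C(/SCc2ccc(Cl)c(Cl)c2)C(=O)c2ccc(Cl)cc2)c(OC)c1` gives 10000 nM, the higher of the two numbers, with compound 1 standing a gap below it that goes beyond the scatter. For compound 3 `O=C(/C(=C\c1ccc(O)c([N+](=O)[O-])c1)SCc1ccc(Br)cc1)c1ccc(O)cc1O` this assay reports only a limit, > 100000 nM, and not a number.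

Compound 4 `COc1cc(OC)c(/C=C(/SCc2ccc(F)cc2)C(=O)c2ccc(Cl)cc2)c(OC)c1` has not yet been measured. It differs from compound 2 in one place: 4-fluorophenyl in place of 3,4-dichlorophenyl on a saturated chain carbon bound to a sulfur. Among the measured compounds shown here, no measured pair shows this exact change, so its effect in this assay is open. A small shift toward a higher number, a 1.5-fold higher number from compound 2 to compound 4 (0.18 log units; within the scatter), is expected, within the scatter of the value of compound 2. Compound 4 is estimated at 15000 nM, most likely between 4000 nM and 60000 nM.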

Compound 4, concentration for 50% growth inhibition: 10000 nM
For compound 4 the middle estimate is 1.5-fold (0.18 log units) above the measured one; the measured number falls inside the stated range.
By their numbers in this assay, from the lowest: compound 1; then compounds 2 and 4 (each within the scatter of the next). At a limit, above all of these: compound 3.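

In this assay, 4-fluorophenyl in place of 3,4-dichlorophenyl on a saturated chain carbon bound to a sulfur gives no change at the digits printed from compound 2 to compound 4 (within the scatter). Among the compounds shown here, no earlier pair differed in one place only, so this is the first direct reading at this position, and here these two halogen-bearing rings cannot be told apart. No measurement shown gives a reason for this. Still open, going by these compounds, is whether this position needs an aromatic ring at all, or whether an amine or a carboxylic acid on the chain would do. Also open, on these data alone, is whether the same change would read alike on the core of compound 1.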